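The source may hold more compounds than are shown below. What is called first, only, known or untested is meant among the compounds shown, and "the series" means these compounds.

Measured compounds in a functional assay for agonist activity at G protein-coupled receptor 88 (Homo sapiens), read by HTRF and cAMP accumulation; on this read-out lower numbers stand for an effect already at smaller amounts and higher numbers for an effect only at larger amounts of compound:

Compound 1 `CN[C@@H](CC(C)C)CN(C(=O)[C@@H]1C[C@H]1c1ccccc1)c1ccc(-c2ccccc2)cc1` gives 2 nM.
Compound 2 `CC[C@H](C)[C@@H](CN(C(=O)[C@@H]1C[C@H]1c1ccccc1)c1ccc(-c2ccccc2)cc1)NC(C)=O` gives 5.8 nM.
Compound 3 `CC(C)(N)CN(C(=O)[C@@H]1C[C@H]1c1ccccc1)c1ccc(-c2ccccc2)cc1` gives 1.4 nM.

Compound 3 carries the lowest number of the three; compound 1 sits within the scatter of it, compound 2 lies beyond. The two steps beyond the scatter both involve compound 2: a 2.9-fold higher number from compound 1 to compound 2 (0.46 log units; beyond the scatter) and a 4.1-fold lower number from compound 2 to compound 3 (0.62 log units; beyond the scatter), and both turn on an acetamido group replacing a free amine. Between the two free amines the step is small: a 1.4-fold lower number from compound 1 to compound 3 (0.15 log units; within the scatter).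

Compound 4 `CC(C)(C)[C@H](N)CN(C(=O)[C@@H]1C[C@H]1c1ccccc1)c1ccc(-c2ccccc2)cc1` differs from compound 3 by 1-amino-2,2-dimethylpropyl in place of 1-amino-1-methylethyl on a saturated chain carbon bound to an amide-type nitrogen. The amine stays free, as in compound 3 and compound 1, and only the carbon chain beside it grows; the comparison of compound 1 with compound 3 shows that a larger chain on a free amine moves the number little. The step of a 1.8-fold higher number from compound 3 to compound 4 (0.25 log units; within the scatter) is therefore expected to stay within the scatter, leaning if anything slightly upward. Compound 4 is estimated at 2.5 nM, with a range of 1 nM to 7 nM.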

Compound 4, half-maximal effective concentration: 11 nM
Beside the measured number, compound 4's estimate is 4.4-fold (0.64 log units) below it; measured number above the stated range.
By their numbers in this assay, from the lowest: compounds 3 and 1 (each within the scatter of the next); then compounds 2 and 4 (each within the scatter of the next).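

In this assay, a free amine at this position does not by itself hold the number down: a 7.9-fold higher number from compound 3 to compound 4 (0.90 log units; beyond the scatter) and a 5.5-fold higher number from compound 1 to compound 4 (0.74 log units; beyond the scatter) show that the carbon chain can matter even when the amine is kept, although the larger chain of compound 1 stays within the scatter of compound 3. Within the data shown here, the acetamido group of compound 2 is also no longer the only change here to give a step beyond the scatter, and a 1.9-fold higher number from compound 2 to compound 4 (0.28 log units; within the scatter) places compound 4 within the scatter of compound 2. No measurement shown gives a reason for the shift with 1-amino-2,2-dimethylpropyl.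

On these data alone, it remains open whether the shift follows the quaternary carbon of the 2,2-dimethylpropyl chain or the chain's overall size, which a 1-amino-2-methylpropyl group would help to separate. As far as these compounds go, the opposite stereocentre of 1-amino-2,2-dimethylpropyl and its methylamino form also remain open.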